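The source may report more compounds than this note shows. Statements on the series, on what has been measured and on what is new or still open speak of the compounds shown alone.

Compound 1 `SC1=NC(n2nc(-c3ccccc3)nc2-c2ccccc2)=CC(c2ccc(Cl)cc2)N1` is the reference point of the series. In a functional assay on the whole organism with Mus musculus as the target, in the maximal electroshock model, with a stated time of 0.5 h (a lower number here means that less compound is needed, a higher number that more compound is needed for the effect), compound 1 gives 30 mg/kg. Compound 2 `SC1=NC(n2nc(-c3ccccc3)nc2-c2ccccc2)=CC(c2ccc(-c3ccccc3)cc2)N1` differs from compound 1 only by phenyl in place of chloro on an aromatic carbon, and in this assay compound 2 gives 100 mg/kg. For the measured compounds named here, the single measured step, a 3.3-fold higher number from compound 1 to compound 2 (0.52 log units; beyond the scatter), is all that is known so far. Of the two numbers, compound 2 holds the highest, and its nearest neighbour is compound 1 at the lower value.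

Compound 3 `SC1=NC(n2nc(-c3ccccc3)nc2-c2ccccc2)=CC(c2ccc(Br)cc2)N1` has not yet been measured in this assay. Relative to compound 2 the change is bromo in place of phenyl on an aromatic carbon. Going by the values given here, the one step that bears on it is a 3.3-fold higher number from compound 1 to compound 2 (0.52 log units; beyond the scatter): the phenyl that entered there is the group that leaves here, and chloro and bromo are each a single heavy atom on the same aromatic carbon. A reversal of roughly that size, in the opposite direction, is therefore expected in this assay, and the expected step is a 3.3-fold lower number from compound 2 to compound 3 (0.52 log units; beyond the scatter). On that basis compound 3 is estimated at 30 mg/kg, with a range from 15 mg/kg to 70 mg/kg.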

Compound 3, minimum effective dose: 100 mg/kg
For compound 3 the middle estimate is 3.3-fold (0.52 log units) below the measured one, and the stated range ends below it.
By their numbers in this assay, from the lowest: compound 1; then compounds 2 and 3 (each within the scatter of the next).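

Within this assay, the exchange of phenyl for bromo gives no change at the digits printed from compound 2 to compound 3 (within the scatter) even though six heavy atoms leave and a single heavy atom enters, so the 4-phenylphenyl and 4-bromophenyl groups cannot be told apart here. For the compounds shown here, the exchange between the two halogens gives a 3.3-fold higher number from compound 1 to compound 3 (0.52 log units; beyond the scatter) and is the only change at this position, besides the exchange of chloro for phenyl, that lies beyond the scatter; a single heavy atom on this aromatic carbon is therefore not enough to give the number seen with compound 1, and heavy-atom count does not order the three compounds. No measurement on hand explains the separation of chloro from bromo.

Still open, as far as these compounds go, is whether the lower number belongs to chloro alone or also appears with fluoro, methyl or methoxy on the same carbon. Also open, from the compounds shown here alone, are the results with an amine or a carboxylic acid at this position, and whether the separation of chloro from bromo persists when the rest of the shared core is changed.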